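The source may report more compounds than this note shows. Statements on the series, on what has been measured and on what is new or still open speak of the compounds shown alone.

In a functional assay on Lewis lung carcinoma cells for cytotoxicity against Lewis lung carcinoma cell line (Mus musculus), read by MTT assay, with a stated time of 72 h (on this read-out lower numbers stand for stronger inhibition and higher numbers for weaker inhibition), compound 1 `COc1ccc(/C=C2\COC/C(=C\c3ccccc3F)C2=O)cc1O` gives 9600 nM and compound 3 `COc1cc(/C=C2\COC/C(=C\c3ccccc3F)C2=O)ccc1O` gives 13100 nM while compound 2 `O=C1/C(=C/c2cccc(O)c2)COC/C1=C\c1ccccc1F` gives 13800 nM and so stands within the usual scatter of both. Compound 4 `COc1ccccc1/C=C1\COC/C(=C\c2ccccc2F)C1=O` is not yet measured. It has 2-methoxyphenyl in place of 3-hydroxyphenyl on a double-bonded chain carbon bound to a double-bonded ring carbon. Within the data shown here, the one measured step that bears on this is a 1.4-fold higher number from compound 1 to compound 2 (0.16 log units; within the scatter) and it stays within the scatter. On these data alone, all three measured compounds carry a hydroxy group and compound 4 does not, so that loss remains untested. The expected step is a 1.3-fold lower number from compound 2 to compound 4 (0.10 log units; within the scatter) and no shift beyond the scatter is expected. Compound 4 is estimated at 11000 nM with an expected range from 5000 nM to 25000 nM in this assay once tested.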

Compound 4, half-maximal inhibitory concentration: 15400 nM
Compound 4: middle estimate off by 1.4-fold (0.15 log units), on the low side; low and high end bracket the measured number.
By their numbers in this assay, from the lowest: compounds 1, 3, 2 and 4 (each within the scatter of the next).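

In this assay putting 2-methoxyphenyl in place of 3-hydroxyphenyl on a double-bonded chain carbon bound to a double-bonded ring carbon gives a 1.1-fold higher number from compound 2 to compound 4 (0.05 log units; within the scatter) even though the hydrogen-bond donor is gone. Among these compounds, compounds 1, 2 and 3 all carry a hydroxy group, so compound 4 is the first to show that a number in this range does not require one. No measurement here gives a reason for this result. On these data alone, whether an amine or a carboxylic acid on this aromatic ring would give a step beyond the scatter remains open.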